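The source may report more compounds than this note shows. Statements on the series, on what has been measured and on what is new or still open speak of the compounds shown alone.

Working notes on the series. Three compounds have a number in a functional assay (muscle tissue) with Cavia porcellus as the target; a lower number here means that less compound is needed, a higher number that more compound is needed for the effect. Compound 1 `COC(=O)C1=C(C)N=C(C)/C(=C(\O)OC)C1c1cc([N+](=O)[O-])ccc1O` gives 100 nM in this assay. Compound 2 `COC(=O)C1=C(C)N=C(C)/C(=C(\O)OC)C1c1ccc(Cl)cc1Cl` gives 640 nM. Compound 3 `CCOc1ccccc1C1C(C(=O)OC)=C(C)N=C(C)/C1=C(\O)OC` gives 110 nM. Compound 2 thus stands at the highest of the three numbers, beyond the scatter from both compound 3 and compound 1, which sit close to one another. The next compound, compound 4 `COC(=O)C1=C(C)N=C(C)/C(=C(\O)OC)C1c1cccc(OC)c1`, differs from compound 2 in one place: 3-methoxyphenyl in place of 2,4-dichlorophenyl on a saturated ring carbon. Among the measured compounds shown here, no measured pair isolates this change, so the expectation rests on compound 2 alone. For compound 4 a step toward a lower number, beyond the scatter, is estimated: a 2.6-fold lower number from compound 2 to compound 4 (0.41 log units; beyond the scatter). Compound 4 is therefore expected to give about 250 nM in this assay, within a range of 60 nM to 1000 nM.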

Compound 4, half-maximal effective concentration: 191 nM
Compound 4: middle estimate off by 1.3-fold (0.12 log units), on the high side; measured number inside the range.
By their numbers in this assay, from the lowest: compounds 1, 3 and 4 (each within the scatter of the next); then compound 2.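

In this assay the group on the saturated ring carbon proves able to move the number, with a 3.4-fold lower number from compound 2 to compound 4 (0.53 log units; beyond the scatter) on 3-methoxyphenyl in place of 2,4-dichlorophenyl. Among the compounds shown here, this is the first single-place step, so the position now has a measured step behind it. No measurement at hand accounts for this step.

The pair cannot separate the loss of the chlorine atoms from the gain of the methoxy group. From the compounds shown here alone, how a cyclohexyl group or a pyridine ring would read at this position remains open.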